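A few compounds are considered here, and "the series" means these few. Any claim that something is new, unique, unknown or untested is made for them only; others in the source may bear on it.

Three members of the series have been run in a functional assay on the whole organism (strain Wistar albino) for inhibition, with Rattus norvegicus as the target, read by paw edema, with a stated time of 2 h, at a dose of 25 mg/kg by the oral route; on this read-out higher numbers stand for more inhibition at the one dose given (going by the name of the read-out) and lower numbers for less inhibition. Compound 1, `Cc1ccc(Nc2nn(-c3ccc([N+](=O)[O-])cc3)c3nc(Nc4ccccc4)n(-c4ccccc4)c(=O)c23)cc1`, gives 39.8%. Within the data shown here, compound 2, `Cc1ccc(Nc2nn(-c3ccc(S(N)(=O)=O)cc3)c3nc(Nc4ccccc4)n(-c4ccccc4)c(=O)c23)cc1`, gives 63.4% in this assay; the single structural difference from compound 1 is sulfamoyl in place of nitro on an aromatic carbon, and the step is a number 23.6 percentage points higher from compound 1 to compound 2 (beyond the scatter). Compound 3, `O=c1c2c(Nc3ccc(Cl)cc3)nn(-c3ccc([N+](=O)[O-])cc3)c2nc(Nc2ccccc2)n1-c1ccccc1`, gives 39% in this assay; the step of a number 0.8 percentage points lower from compound 1 to compound 3 (within the scatter) leaves compound 1 and compound 3 within the scatter of each other, so no order between them is drawn. Between compound 2 and compound 3 the gap lies beyond the scatter.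

Compound 4, `NS(=O)(=O)c1ccc(-n2nc(Nc3ccc(Cl)cc3)c3c(=O)n(-c4ccccc4)c(Nc4ccccc4)nc32)cc1`, is not yet measured in this assay. It differs from compound 3 by sulfamoyl in place of nitro on an aromatic carbon. The core of compound 3 differs from the core of compound 1 by chloro in place of methyl on an aromatic carbon. The change made from compound 3 to compound 4 is the same change that was made from compound 1 to compound 2; among the compounds shown it occurs twice, and the place line reads the same word for word in both, so it is treated as the same change rather than merely the same kind.

The step expected is a number 23 percentage points higher from compound 3 to compound 4 (beyond the scatter), set beside the measured a number 23.6 percentage points higher from compound 1 to compound 2 (beyond the scatter); this rests on that one measured instance, and on compound 3 giving 39%, a value within the scatter of compound 1. Compound 4 is accordingly estimated at 62% in this assay, with an expected range from 50% to 74%.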

Compound 4, a percentage reported as inhibition, in the whole organism at one dose (the size of the read-out at that dose, not a potency): 56.3%
Compound 4: the middle estimate sits 5.7 percentage points above what was measured; measured number inside the range.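

In this assay, sulfamoyl in place of nitro on an aromatic carbon carries over to the core bearing chloro, with a number 17.3 percentage points higher from compound 3 to compound 4 (beyond the scatter), and the size of the step holds up against the earlier instance: the same change on two cores in this assay, a number 23.6 percentage points higher (beyond the scatter) from compound 1 to compound 2 and a number 17.3 percentage points higher (beyond the scatter) from compound 3 to compound 4, 6.3 percentage points apart, within the scatter of two such steps
Read the other way, chloro in place of methyl on an aromatic carbon, with a number 7.1 percentage points lower from compound 2 to compound 4 (within the scatter), stays within the scatter whichever of the two groups, nitro or sulfamoyl, is present, so the two changes can be treated as additive across these four compounds: the same change on two cores in this assay, a number 0.8 percentage points lower (within the scatter) from compound 1 to compound 3 and a number 7.1 percentage points lower (within the scatter) from compound 2 to compound 4, 6.3 percentage points apart, within the scatter of two such steps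
This rests on a single pair of cores that differ only by chloro or methyl, at one dose and one time, so it shows neither that the sulfamoyl step would carry over to a core differing in any other place nor why the step occurs.

The compounds shown leave open whether the rise belongs to sulfamoyl itself or would also appear with another group on that aromatic carbon, such as a carboxylic acid, an amine or methylsulfonyl. They also leave open how the step behaves with groups other than methyl and chloro on the other aromatic ring, for instance methoxy or a longer alkyl chain.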